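The compounds below may be only part of what the source reports. "The series", "measured", "known", "first", "only" and "open" are said of these compounds alone.

Measured in a physicochemical assay for solubility, with a stated time of 4 h, at pH 2.0; a lower number here means a less soluble compound, a higher number a more soluble compound:
- compound 1 `Cc1cc(/C=C/C#N)cc(C)c1Oc1cc(Nc2ccc(C#N)cc2)c(N)cc1[N+](=O)[O-]`: 0.29 ug/mL
- compound 2 `Cc1cc(CCC#N)cc(C)c1Oc1cc(Nc2ccc(C#N)cc2)c(N)cc1C(N)=O`: 9.11 ug/mL

Compound 1 holds the lower of the two numbers, and compound 2 stands higher, beyond the usual scatter. Compound 3 `Cc1cc(/C=C/C#N)cc(C)c1Oc1cc(Nc2ccc(C#N)cc2)c(N)cc1C(F)(F)F` carries trifluoromethyl in place of nitro on an aromatic carbon. Among the compounds with values here, the data hold no measured step between compounds differing in one place, so the size of this change in this assay is poorly constrained. The expectation starts from compound 1 at 0.29 ug/mL, with no shift beyond the scatter in either direction. The expected change is a 1.2-fold lower number from compound 1 to compound 3 (0.06 log units; within the scatter). For compound 3 the estimate is 0.25 ug/mL, with an expected range of 0.06 ug/mL to 1 ug/mL.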

Compound 3, solubility: 0.42 ug/mL
Beside the measured number, compound 3's estimate is 1.7-fold (0.23 log units) below it, and the stated range covers the measured number.
By their numbers in this assay, from the lowest: compounds 1 and 3 (each within the scatter of the next); then compound 2.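

At the position para to a (4-cyanophenyl)amino group, trifluoromethyl in place of nitro gives a 1.4-fold higher number from compound 1 to compound 3 (0.16 log units; within the scatter) in this assay, the first single-place step available in this series. On this core, therefore, the exchange does not separate the two groups beyond the scatter. No measured evidence bears on the reason for this result.

Still open, as far as these compounds go, is how a carboxylic acid or a dimethylamino group at this position would read in this assay. Also open, from the compounds shown here alone, is whether the same exchange reads alike with a saturated nitrile chain on the core.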